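Methyl to trifluoromethyl on a benzimidazolone series, cytotoxicity

This account rests on a few compounds, and the source may have more. Where it says the series, first, only, none or still open, it means among the compounds named here.

Compound 2 `Cc1cc(C)cc(Cn2c(=O)[nH]c3ccc(C)cc32)c1` gives 856 nM in an ADME assay on MT4 cells (Homo sapiens) for cytotoxicity; a higher number here means that more compound is tolerated, a lower number that less compound is tolerated. Compound 3 `Cc1cc(C)cc(Cn2c(=O)[nH]c3ccc(C(F)(F)F)cc32)c1` gives 37400 nM; the change is trifluoromethyl in place of methyl on an aromatic carbon, and it made a step of a 44-fold higher number from compound 2 to compound 3 (1.64 log units; beyond the scatter). Compound 1 `Cc1ccc2[nH]c(=O)n(Cc3c(F)cccc3F)c2c1` gives 236000 nM, the highest of the three; the difference between the core of compound 1 and that of compound 2 is not broken down here. Compound 4 `O=c1[nH]c2ccc(C(F)(F)F)cc2n1Cc1c(F)cccc1F` is not yet measured; it differs from compound 1 by trifluoromethyl in place of methyl on an aromatic carbon, the same change seen between compound 2 and compound 3. Among the compounds with values here, a step of a 1.7-fold higher number from compound 1 to compound 4 (0.23 log units; within the scatter) is expected, smaller than the earlier one because compound 1 already stands at 236000 nM, the highest number measured so far. The estimate for compound 4 is 400000 nM, between 150000 nM and 1500000 nM.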

Compound 4, half-maximal cytotoxic concentration: > 424000 nM
Compound 4: a limit, no number; the forecaster's own chance of this, stated with the estimate: 40%; middle value at least 1.0-fold (0.02 log units) from the limit.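

In this assay the change on the core of compound 1 gives an at least 1.7-fold higher number from compound 1 to compound 4 (0.25 log units; that floor lies within the scatter), so the direction seen on the other core is not contradicted, though this floor alone does not confirm it. Compound 4 carries a limit and not a number: the limit of > 424000 nM in this assay, at which 1 of the 4 values shown sits. The two steps therefore do not show that the change carries from one core to the other with the same size: the same change on two cores in this assay, a 44-fold higher number (1.64 log units; beyond the scatter) from compound 2 to compound 3 and an at least 1.7-fold higher number (0.25 log units; that floor lies within the scatter) from compound 1 to compound 4; the limit leaves it open whether they differ.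

The compounds shown leave open whether the step holds on any further core. They also leave open how a nitrile, a carboxylic acid or an amine in place of trifluoromethyl on this aromatic carbon would read in this assay.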